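The source may report more compounds than this note shows. Statements on the series, on what has been measured and on what is new or still open speak of the compounds shown alone.

Measured in a functional assay on LoVo cells (Homo sapiens) for inhibition, read by MTT assay, with a stated time of 24 h; a lower number here means a stronger inhibitor, a higher number a weaker inhibitor:
compound 1 `CC1(C)[C@H]2CC[C@]1(C)N(Cc1cn(-c3ccccc3Br)nn1)C(=O)C2`: 60 nM
compound 2 `CC1(C)[C@H]2CC[C@]1(C)N(Cc1cn(-c3ccccc3Cl)nn1)C(=O)C2`: 190 nM
compound 3 `CC1(C)[C@H]2CC[C@]1(C)N(Cc1cn(-c3ccc(O)cc3)nn1)C(=O)C2`: 410 nM

Compound 3 has the highest number of the three and is the weakest inhibitor here. The gaps to it are a 2.2-fold higher number from compound 2 to compound 3 (0.33 log units; beyond the scatter) and a 6.8-fold higher number from compound 1 to compound 3 (0.83 log units; beyond the scatter). Next comes compound 4 `CC1(C)[C@H]2CC[C@]1(C)N(Cc1cn(-c3ccc(Br)cc3)nn1)C(=O)C2`, which keeps the shared core and carries bromo in place of hydroxy on an aromatic carbon, para to a large group: bromo in place of hydroxy on an aromatic carbon. Among the measured compounds shown here, no measured step isolates this exchange at this place. The closest evidence is that both halogen-bearing compounds give lower numbers than the hydroxy compound, as those two gaps show, while a 3.2-fold higher number from compound 1 to compound 2 (0.50 log units; beyond the scatter) favours bromo over chloro. The halogens in compound 1 and compound 2 do not sit where the bromo sits in compound 4, so this support is indirect. A modest step to a lower number is therefore expected in this assay. The estimate amounts to a 2.7-fold lower number from compound 3 to compound 4 (0.44 log units; beyond the scatter). Compound 4 is estimated at 150 nM, with an expected range of 50 nM to 400 nM.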

Compound 4, half-maximal inhibitory concentration: 60 nM
Beside the measured number, compound 4's estimate is 2.5-fold (0.40 log units) above it, and the stated range covers the measured number.
By their numbers in this assay, from the lowest: compounds 1 and 4 (each within the scatter of the next); then compound 2; then compound 3.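

The exchange at this place is now measured directly: in this assay, bromo in place of hydroxy on an aromatic carbon, para to a large group, gives a 6.8-fold lower number from compound 3 to compound 4 (0.83 log units; beyond the scatter) for this pair. Comparing bromo placements, 4-bromophenyl in place of 2-bromophenyl gives no change at the digits printed from compound 1 to compound 4 (within the scatter) and so does not separate these two compounds, while 4-bromophenyl in place of 2-chlorophenyl gives a 3.2-fold lower number from compound 2 to compound 4 (0.50 log units; beyond the scatter) in the same read-out. No measurement at hand accounts for these steps.

On these data alone, how an amine or a carboxylic acid on the same aromatic carbon would read in this assay remains open. Also open, as far as these compounds go, is whether chloro at that place would give a higher number than bromo, as it does on the 2-substituted phenyl pair.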